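A few compounds are considered here, and "the series" means these few. Any claim that something is new, unique, unknown or untested is made for them only; others in the source may bear on it.

Measured in an ADME assay on MCF7-DOX cells (Homo sapiens) for cytotoxicity, read by MTT assay, with a stated time of 48 h; a lower number here means a stronger inhibitor, a higher number a weaker inhibitor:
- Compound 1 `COc1cc(OC)c(C(=O)/C=C/c2cccc(F)c2)c(O)c1CC=C(C)C`: 45400 nM
- Compound 2 `COc1cc(OC)c(C(=O)/C=C/c2ccc(N3CCN(C(=O)OC(C)(C)C)CC3)cc2)c(O)c1CC=C(C)C`: > 100000 nM, a limit of the assay and not a number
- Compound 3 `COc1cc(O)c(C(=O)/C=C/c2ccc(N3CCN(C(=O)OC(C)(C)C)CC3)cc2)c(OC)c1`: 47300 nM

Compound 2 gives no number, only (the limit of > 100000 nM in this assay, at which 1 of the 3 values shown sits). Compound 4 `COc1cc(OC)c(C(=O)/C=C/c2ccc(N3CCNCC3)cc2)c(O)c1CC=C(C)C` has hydrogen in place of tert-butoxycarbonyl on an amine nitrogen in a ring. Within the data shown here, no measured step makes this change. Among the measured compounds shown here, the one measured step, an at least 2.1-fold lower number from compound 2 to compound 3 (0.32 log units; beyond the scatter), is at least modest but lies at another place, with hydrogen in place of 3-methylbut-2-en-1-yl on an aromatic carbon, so it offers only a rough guide to size. On that guide, a change of similar or somewhat larger size toward a lower number is expected, estimated as an at least 4.0-fold lower number from compound 2 to compound 4 (0.60 log units; beyond the scatter). For compound 4 the expected value is 25000 nM, with an estimated range of 7000 nM to 80000 nM.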

Compound 4, half-maximal inhibitory concentration: 57800 nM
For compound 4 the middle estimate is 2.3-fold (0.36 log units) below the measured one; low and high end bracket the measured number.
By their numbers in this assay, from the lowest: compounds 1, 3 and 4 (each within the scatter of the next). At a limit, above all of these: compound 2.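

In this assay compound 2 is a limit and not a number: the limit of > 100000 nM in this assay, at which 1 of the 4 values shown sits.
Hydrogen in place of tert-butoxycarbonyl on the amine nitrogen in the ring gives an at least 1.7-fold lower number from compound 2 to compound 4 (0.23 log units; that floor lies within the scatter), so the size of this step stays unfixed. Even so, this is the first reading at this nitrogen, and it yields a measured number where tert-butoxycarbonyl gave only a limit.

Open, on these data alone, is what a methyl, an acetyl or a longer alkyl chain on this nitrogen would give. Also open, as far as these compounds go, is whether hydrogen here has a like effect on the core of compound 3, which lacks 3-methylbut-2-en-1-yl.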